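The compounds below may be only part of what the source reports. "The series", "measured", "known", "first", "only" and "open" are said of these compounds alone.

In an in vitro ADME assay on microsomes (Homo sapiens) for metabolic stability (on this read-out higher numbers stand for a longer-lived compound and lower numbers for a shorter-lived compound), compound 1 (`CCc1nc(-c2ccc(OC)cc2OC(F)(F)F)c(CC)nc1NC(CC)CC`) gives 0.267 h. Compound 2 (`CCc1nc(-c2ccc(Cl)cc2Cl)c(CC)nc1NC(C1CC1)C1CC1`) gives 0.183 h and compound 3 (`CCc1nc(N(CC2CC2)CC2CC2)c(CC)nc1-c1ccc(Cl)cc1Cl`) gives 0.133 h. Compound 1 has the highest number of the three, but all three values lie within the scatter of one another, so it does not clearly stand apart.

Compound 4 (`CCc1nc(-c2ccc(OC)cc2C(F)(F)F)c(CC)nc1NC(CC)CC`) differs from compound 1 by one change: trifluoromethyl in place of trifluoromethoxy on an aromatic carbon. Trifluoromethyl takes the place of trifluoromethoxy on an aromatic carbon, ortho to a large group and meta to a methoxy group.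

Among the measured compounds shown here, no measured pair carries this replacement. For the measured compounds named here, the only measured step, a 1.4-fold lower number from compound 2 to compound 3 (0.14 log units; within the scatter), involves a different group elsewhere on the molecule, so it bears only indirectly and shows how small a single change can be in this small set. Nothing therefore points to a move in either direction in this assay, and no change beyond the scatter is expected. The estimated step is a 1.0-fold higher number from compound 1 to compound 4 (0.00 log units; within the scatter).

For compound 4 the estimated half-life is 0.27 h, with an expected range from 0.14 h to 0.52 h.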

Compound 4, half-life: 0.2 h
Beside the measured number, compound 4's estimate is 1.4-fold (0.13 log units) above it, within the range that was stated.
By their numbers in this assay, from the lowest: compounds 3, 2, 4 and 1 (each within the scatter of the next).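

Among the compounds shown here, the pair gives the first direct reading at this position. In this assay, with trifluoromethyl in place of trifluoromethoxy on an aromatic carbon, ortho to a large group and meta to a methoxy group, the result is a 1.3-fold lower number from compound 1 to compound 4 (0.13 log units; within the scatter). The oxygen of the trifluoromethoxy group can therefore go at this place without a step beyond the scatter, at least on the core of compound 1, and no available measurement accounts for the step or ties it to a property of either group.

Going by these compounds, whether a nitrile or a plain methyl group on this carbon would move the half-life beyond the scatter remains open. So does whether the same replacement would read alike in a compound carrying the (dicyclopropylmethyl)amino group of compound 2, as the change is seen here in a single pair.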